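The compounds below may be only part of what the source reports. "The series", "measured", "known", "first", "only" and "open" are said of these compounds alone.

Compound 1 `CCC[C@@H](NC(=O)c1ccc(Cl)s1)C(=O)Nc1ccc(N2CCOCC2=O)c(C)c1` and compound 2 `COC[C@@H](NC(=O)c1ccc(Cl)s1)C(=O)Nc1ccc(N2CCOCC2=O)c(F)c1` share the same core and were both tested in an assay on isolated protein for inhibition of Trypsin (Homo sapiens); a higher number here means a weaker inhibitor, a lower number a stronger inhibitor. In this assay compound 1 gives > 10000 nM, which is a limit of the assay rather than a number. In this assay compound 2 likewise gives > 10000 nM, again a limit and not a number. Going by the values given here, no step joins these two compounds, since compound 2 differs from compound 1 in more than one place; the pair shows only that both sit at the limit of > 10000 nM in this assay, at which 2 of the 2 values shown sit. Compound 1 therefore stands only at a limit, with no number that could place it against anything else. Compound 3 `CCCOC[C@@H](NC(=O)c1ccc(Cl)s1)C(=O)Nc1ccc(N2CCOCC2=O)c(C)c1` has not yet been measured. It differs from compound 1 by propoxy in place of ethyl on a saturated chain carbon, two bonds along the chain from an amide-type nitrogen and a carbonyl carbon. Among the compounds with values here, with no measured step to lean on, the expected step is a step that the limit leaves unreadable from compound 1 to compound 3, that is, nothing beyond the usual scatter. Compound 3 is accordingly expected to give 20000 nM in this assay, with a range from 5000 nM to 100000 nM, and most likely the assay will once more report only a limit.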

Compound 3, half-maximal inhibitory concentration: > 10000 nM
Compound 3 gave a limit, no number; the forecaster's own chance of this, stated with the estimate: 85%; the middle value does not contradict the limit.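

No new step can be read between compound 1 and compound 3, since each gives only a limit of the assay and no number: (the limit of > 10000 nM in this assay, at which 3 of the 3 values shown sit). The compounds shown leave open how strongly any of them inhibits in this assay, and so whether propoxy in place of ethyl makes any difference there.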